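Swapping selenium for sulfur in a salicylate side chain

The source may hold more compounds than are shown below. What is called first, only, known or untested is meant among the compounds shown, and "the series" means these compounds.

Compound 1, `CC(=O)Oc1ccccc1C(=O)NCC[Se]C#N`, gives 21100 nM in a functional assay on MDA-MB-231 cells (Homo sapiens) for antiproliferative activity, read by MTT assay, with a stated time of 24 h; a higher number here means a weaker inhibitor, a lower number a stronger inhibitor.
Compound 2, `CC(=O)Oc1ccccc1C(=O)[Se]CC[Se]C(=O)c1ccccc1OC(C)=O`, gives 18600 nM in this assay.
Compound 3, `C[Se]CC(NC(=O)c1ccccc1OC(C)=O)C(=O)O`, gives > 50000 nM in this assay.

Of the compounds shown here, three built on the same acetylated salicylamide core have been measured. Compound 1 stands alongside compound 2 in this assay, the two numbers lying within the usual scatter of each other, so neither can be called the stronger inhibitor. Compound 3 gives only a limit of the assay rather than a number: the limit of > 50000 nM in this assay, at which 1 of the 3 values shown sits.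

Compound 4, `CC(=O)Oc1ccccc1C(=O)NCCSC#N`, has not yet been measured. It differs from compound 1 in one place: a group of 3 heavy atoms (1 carbon, 1 nitrogen, 1 sulfur; no ring) in place of a group of 3 heavy atoms (1 carbon, 1 nitrogen, 1 selenium; no ring), on a saturated chain carbon, two bonds along the chain from an amide-type nitrogen. Going by the values given here, no step between two measured compounds touches this change, so there is nothing in the measured set that tells how large a move it brings. The expectation is a modest shift toward a weaker inhibitor, though a result within the scatter of compound 1 is also plausible. The step from compound 1 to compound 4 is expected to be a 1.7-fold higher number from compound 1 to compound 4 (0.22 log units; within the scatter). For compound 4 the estimate in this assay is 35000 nM, with a likely range from 15000 nM to 80000 nM.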

Compound 4, half-maximal inhibitory concentration: > 50000 nM
Compound 4 gave a limit, no number; the forecaster's own chance of this, stated with the estimate: 30%; middle value at least 1.4-fold (0.15 log units) away from the limit.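

In this assay, going by these compounds alone, putting cyanosulfanyl in place of the selenium-bearing group, on a saturated chain carbon, two bonds along the chain from an amide-type nitrogen, brings an at least 2.3-fold higher number from compound 1 to compound 4 (0.37 log units; beyond the scatter), the first step in this set that can be read at this position. With the rest of the molecule unchanged, exchanging selenium for sulfur at this one atom is enough to produce a change beyond the usual scatter, so for this pair the selenium atom matters for the antiproliferative effect. Compound 4 gives a limit of the assay and not a number, so the printed step is only a minimum, and compound 4 now belongs with the compounds that reach that limit: the limit of > 50000 nM in this assay, at which 2 of the 4 values shown sit.

The compounds shown do not tell how far the loss extends or why it occurs, and they do not show whether the same exchange would have a similar effect on another selenium-bearing side chain. As far as these compounds go, it also remains open how this position would respond to a longer chain between the amide-type nitrogen and the selenium, or to an amine or a carboxylic acid in place of the nitrile.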